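The source may hold more compounds than are shown below. What is called first, only, known or untested is meant among the compounds shown, and "the series" means these compounds.

Measured in an assay on membranes from CHO cells for displacement of a labelled ligand from adenosine receptor A1 (Homo sapiens), read by scintillation counting, with a stated time of 60 min, tested at 1 uM; on this read-out lower numbers stand for less inhibition and higher numbers for more inhibition at the one concentration tested (going by the name of the read-out):
compound 1 `CCN(CC)C(=O)C1=C(C)NC(=O)NC1c1ccoc1`: 15%
compound 2 `CC1=C(C(=O)SC(C)C)C(c2ccoc2)NC(=O)N1`: 9%
compound 3 `CC1=C(C(=O)OC2CCCC2)C(c2ccco2)NC(=O)N1`: 1%

Compound 3 stands at the lowest of the three numbers; its gap to compound 2 lies within the scatter, its gap to compound 1 beyond it. Compound 4 `CC1=C(C(=O)OC2CCCC2)C(c2ccoc2)NC(=O)N1` is not yet measured and differs from compound 3 in one place: furan-3-yl in place of furan-2-yl on a saturated ring carbon. Compounds 1 and 2 also carry furan-3-yl, but each differs from compound 3 in a second place as well, so their values give no clean reading of this change on their own. Among the compounds with values here, the one measured step, a number 6 percentage points lower from compound 1 to compound 2 (within the scatter), concerns a different change and does not bear on the furan change. Within the data shown here, no step therefore speaks to the change from compound 3 to compound 4, and the expected step is a number 4 percentage points higher from compound 3 to compound 4 (within the scatter), none beyond the scatter. The value expected for compound 4 in this assay is estimated at 5%, within a range from -5% to 16%.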

Compound 4, a percentage reported as inhibition, at one concentration (the size of the read-out at that concentration, not a potency): 6%
Compound 4: the middle estimate sits 1 percentage points below what was measured, within the range that was stated.
By their numbers in this assay, from the lowest: compounds 3, 4, 2 and 1 (each within the scatter of the next, the first and the last beyond it).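

In this assay the position of attachment of the furan can now be read on its own: with cyclopentyloxy held fixed, furan-3-yl in place of furan-2-yl gives a number 5 percentage points higher from compound 3 to compound 4 (within the scatter), so the two furans are not told apart at this position. With furan-3-yl held fixed, cyclopentyloxy on the carbonyl carbon gives a number 3 percentage points lower from compound 2 to compound 4 (within the scatter) and a number 9 percentage points lower from compound 1 to compound 4 (within the scatter), so neither replacement moves the number beyond the scatter. Nothing measured accompanies these numbers that would explain them.

Going by these compounds, the furan change has been read only with cyclopentyloxy on the carbonyl carbon, so its size with diethylamino or isopropylsulfanyl there remains open. Also open, on these data alone, is whether phenyl or thiophen-3-yl in place of the furan would give a larger number in this assay on this core.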